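Aryl swap at the imine carbon: compound 2 to compound 3

The source may report more compounds than this note shows. Statements on the series, on what has been measured and on what is new or still open speak of the compounds shown alone.

Compound 2 `FC(F)(F)c1ccc(C2=NN(C(=S)Nc3ccccc3)C(c3ccc4c(c3)OCCO4)C2)cc1` gives 43500 nM in a functional assay on A-375 cells (Homo sapiens) for antiproliferative activity, read by MTT assay, with a stated time of 48 h (on this read-out lower numbers stand for stronger inhibition of growth and higher numbers for weaker inhibition of growth), the higher of the two numbers measured. Within the data shown here, compound 1 `Fc1ccc(C2=NN(C(=S)Nc3ccccc3)C(c3ccc4c(c3)OCCO4)C2)cc1` gives 15700 nM, and the step of a 2.8-fold higher number from compound 1 to compound 2 (0.44 log units; beyond the scatter) is the only step measured. Compound 3 `S=C(Nc1ccccc1)N1N=C(c2ccccc2Br)CC1c1ccc2c(c1)OCCO2` carries 2-bromophenyl in place of 4-(trifluoromethyl)phenyl on a carbon with a double bond to nitrogen. Among the measured compounds shown here, no measured step matches this change; the one measured step shows only that trifluoromethyl goes with the higher number, while compound 1 gives 15700 nM without it, so a modest downward step a 2.4-fold lower number from compound 2 to compound 3 (0.38 log units; beyond the scatter) is expected. Compound 3 is estimated at 18000 nM, between 6000 nM and 50000 nM.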

Compound 3, concentration for 50% growth inhibition: > 200000 nM
Compound 3 ended at the assay's limit (the forecaster's own chance of this, stated with the estimate: 10%); middle value at least 11-fold (1.04 log units) away from the limit.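

Compound 3 gives a limit, not a number: the limit of > 200000 nM in this assay, at which 1 of the 3 values shown sits. Read against that limit, the aryl group on this carbon with a double bond to nitrogen carries more weight than the earlier fluoro-to-trifluoromethyl change suggested, with an at least 4.5-fold higher number from compound 2 to compound 3 (0.66 log units; beyond the scatter) and an at least 12-fold higher number from compound 1 to compound 3 (1.10 log units; beyond the scatter), the second printed as large. The 2-bromophenyl group thus stands apart from both aryl groups it replaces, whereas those two differ only modestly.

Whether the bromine itself or its place on the ring accounts for this stays open. So does the outcome with an amine or a carboxylic acid on this aryl ring.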